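Series notes: octyl in place of 4-ethylphenyl

This account rests on a few compounds, and the source may have more. Where it says the series, first, only, none or still open, it means among the compounds named here.

Of the compounds shown here, three have been measured in a functional assay on HeLa cells (Homo sapiens) for cytotoxicity; a higher number here means that more compound is tolerated, a lower number that less compound is tolerated. Compound 1 `CCCc1ccc(-c2cc3cn([C@H]4C[C@H](O)[C@@H](CO)O4)c(=O)nc3s2)cc1` gives > 200000 nM, which is a limit of the assay and not a number. Compound 2 `CCCCCc1ccc(-c2cc3cn([C@H]4C[C@H](O)[C@@H](CO)O4)c(=O)nc3s2)cc1` gives > 200000 nM, again a limit. Compound 3 `CCc1ccc(-c2cc3cn([C@H]4C[C@H](O)[C@@H](CO)O4)c(=O)nc3s2)cc1` gives > 200000 nM, also a limit. Compound 3 therefore stands with the other two at the limit of > 200000 nM in this assay, at which 3 of the 3 values shown sit, and none of the three is separated from the others by a readable step. The step that the two limits leave unreadable from compound 1 to compound 2, the step that the two limits leave unreadable from compound 1 to compound 3 and the step that the two limits leave unreadable from compound 2 to compound 3 cannot be sized, since both ends of each sit at the limit.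

Compound 4 `CCCCCCCCc1cc2cn([C@H]3C[C@H](O)[C@@H](CO)O3)c(=O)nc2s1` is not yet measured. It differs from compound 3 by octyl in place of 4-ethylphenyl on an aromatic carbon. Within the data shown here, no measured step bears directly on this exchange: the three steps measured all alter the saturated chain on the aromatic ring that leaves, and all are unreadable. Among the measured compounds shown here, the only guidance is that compounds 1, 2 and 3 all sit at the limit of > 200000 nM in this assay, at which 3 of the 3 values shown sit, so no step beyond the scatter in either direction can be read from them. Compound 4 is expected to remain at the limit as well, with an expected step of a number no higher from compound 3 to compound 4 (the limit leaves the size open) of no readable size. Compound 4 is estimated at 200000 nM, in the range 80000 nM to 500000 nM.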

Compound 4, half-maximal cytotoxic concentration: 53000 nM
Beside the measured number, compound 4's estimate is 3.8-fold (0.58 log units) above it; the measured number lies below the stated range.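

In this assay, among these compounds, octyl in place of the 4-alkylphenyl groups on this aromatic carbon, next to the ring sulfur, gives the first readable steps (an at least 3.7-fold lower number from compound 3 to compound 4 (0.57 log units; beyond the scatter)) and (an at least 3.7-fold lower number from compound 1 to compound 4 (0.57 log units; beyond the scatter)). The earlier steps among compound 1, compound 2 and compound 3 cannot be read, so this position had shown nothing until the group on it was exchanged as a whole; varying the saturated chain on the phenyl ring left all three compounds at the same limit. The exchange keeps the count of heavy atoms and of carbon, and the counted difference is the six-membered aromatic ring that leaves, while the size of each new step stays open at its upper end: the limit of > 200000 nM in this assay, at which 3 of the 4 values shown sit.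

The compounds shown do not separate the loss of the aromatic ring from the length or flexibility of the octyl chain, and a single comparison cannot tie the step to either. On these data alone, it also remains open how the number moves with a shorter chain such as butyl, a longer chain such as decyl, or an octyl chain ending in an amine or a carboxylic acid.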